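Ethylsulfanyl for cyclopropyl on the carbonyl carbon

A few compounds are considered here, and "the series" means these few. Any claim that something is new, unique, unknown or untested is made for them only; others in the source may bear on it.

Compound 1 `CC1=C(C(=O)C2CC2)C(c2ccco2)NC(=O)N1` gives 7% in an assay on membranes from HeLa cells for displacement of a labelled ligand from adenosine receptor A3 (Homo sapiens), read by scintillation counting, with a stated time of 180 min, tested at 1 uM (on this read-out higher numbers stand for more inhibition at the one concentration tested (going by the name of the read-out) and lower numbers for less inhibition), the second highest of the three measured numbers. Compound 2 `CC1=C(C(=O)C2CC2)C(c2ccoc2)NC(=O)N1` gives 16% and compound 3 `CC1=C(C(=O)C2CC2)C(c2ccsc2)NC(=O)N1` gives 1%. The measured steps are a number 9 percentage points higher from compound 1 to compound 2 (within the scatter), a number 6 percentage points lower from compound 1 to compound 3 (within the scatter) and a number 15 percentage points lower from compound 2 to compound 3 (beyond the scatter). Compound 4 `CCSC(=O)C1=C(C)NC(=O)NC1c1ccco1` differs from compound 1 elsewhere: ethylsulfanyl in place of cyclopropyl on a carbonyl carbon. For the measured compounds named here, none of the measured steps touches this carbonyl carbon; all three exchange the aryl group on a saturated ring carbon, and even the largest is modest. With nothing bearing directly on the change and every measured number low, compound 4 is expected to stay low, with a step of a number 1 percentage points higher from compound 1 to compound 4 (within the scatter) that is not expected to exceed the scatter. Compound 4 is therefore estimated at 8%, between 0% and 25%.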

Compound 4, a percentage reported as inhibition, at one concentration (the size of the read-out at that concentration, not a potency): 14%
For compound 4 the middle estimate is 6 percentage points below the measured one; low and high end bracket the measured number.
By their numbers in this assay, from the lowest: compounds 3, 1, 4 and 2 (each within the scatter of the next, the first and the last beyond it).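

For the compounds shown here, at the carbonyl carbon, which none of the earlier steps touched, ethylsulfanyl in place of cyclopropyl gives a number 7 percentage points higher from compound 1 to compound 4 (within the scatter). Going by these compounds alone, the three-membered ring can therefore give way to an open chain carrying sulfur with no step that stands clear of the scatter, and the number stays low. No measurement at hand bears on what either group does at this position.

On these data alone, whether an ethoxy group, an amine or a longer thioether chain on this carbonyl carbon would raise the number remains open. So does whether ethylsulfanyl would give a similar step alongside the furan-3-yl group of compound 2.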